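Halogen swap on the fused ring: bromo to chloro

The source may report more compounds than this note shows. Statements on the series, on what has been measured and on what is new or still open speak of the compounds shown alone.

Measured so far:
compound 1 `COc1ccc(C2=NN(C3=NC(=O)/C(=C4\C(=O)Nc5ccccc54)S3)C(c3ccc(OC)cc3)C2)cc1` — 100000 nM
compound 2 `COc1ccc(C2=NN(C3=NC(=O)/C(=C4\C(=O)Nc5ccc(Br)cc54)S3)C(c3ccc(OC)cc3)C2)cc1` — 32500 nM

Both compounds share one core and differ only at one carbon of the fused ring. In a functional assay on cells (Cancer cell lines, Homo sapiens) for cytotoxicity, read by sulforhodamine B assay, with a stated time of 48 h (a higher number here means a weaker inhibitor of growth, a lower number a stronger inhibitor of growth), compound 1 gives 100000 nM, while compound 2 gives 32500 nM. Among the compounds with values here, the single measured step is a 3.1-fold lower number from compound 1 to compound 2 (0.49 log units; beyond the scatter). Compound 2 therefore stands at the lowest of the two numbers obtained, with compound 1 as its nearest neighbour at the higher number.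

Compound 3 `COc1ccc(C2=NN(C3=NC(=O)/C(=C4\C(=O)Nc5ccc(Cl)cc54)S3)C(c3ccc(OC)cc3)C2)cc1` is not yet measured. It differs from compound 2 by chloro in place of bromo on an aromatic carbon. Within the data shown here, the only measured step that bears on this change is a 3.1-fold lower number from compound 1 to compound 2 (0.49 log units; beyond the scatter), which shows what placing a halogen on that carbon did relative to hydrogen; no measured step compares two halogens at the same carbon. Since both groups are single heavy atoms, a step in this assay smaller than the measured one is expected, most likely within the scatter, with some chance of a modest drift back toward the number of compound 1. The number expected for compound 3 is 45000 nM, with a range of 20000 nM to 100000 nM. That estimate means an expected step of a 1.4-fold higher number from compound 2 to compound 3 (0.14 log units; within the scatter).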

Compound 3, concentration for total growth inhibition: 21200 nM
Estimate against measurement, compound 3: 2.1-fold (0.33 log units) above; low and high end bracket the measured number.
By their numbers in this assay, from the lowest: compounds 3 and 2 (each within the scatter of the next); then compound 1.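

Replacing bromo by chloro on this aromatic carbon gives a 1.5-fold lower number from compound 2 to compound 3 (0.19 log units; within the scatter) in this assay, so the two halogens cannot be told apart here and neither can be ranked over the other. The change from hydrogen to chloro gives a 4.7-fold lower number from compound 1 to compound 3 (0.67 log units; beyond the scatter), which means that a second halogen now moves the number in the same direction as bromo did, and no compound shown goes against this among the three that differ at this carbon. The data offer no measured account of why a halogen on this carbon lowers the number, or of why the two halogens cannot be separated.

The compounds shown leave open whether the lower number depends on a halogen at all, since only hydrogen, bromo and chloro are compared at this carbon, and fluoro, iodo, methyl, an amine or a carboxylic acid there would each give a different test of that. They also leave open whether the same change would act alike on another carbon of the same six-membered aromatic ring, or with other groups on the rest of the shared core.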